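This account rests on a few compounds, and the source may have more. Where it says the series, first, only, none or still open, it means among the compounds named here.

Measured in a functional assay on KYSE-70 cells for antiproliferative activity against KYSE-70 cell line (Homo sapiens), read by MTT assay, with a stated time of 72 h; a higher number here means a weaker inhibitor, a lower number a stronger inhibitor:
- compound 1 `O=C(Nc1cccc(F)c1)c1cc(=O)[nH]c2cc(F)ccc12`: > 20000 nM (a limit, not a number)
- compound 2 `O=C(Nc1cccc(F)c1)c1cc(=O)[nH]c2cc(-c3ccc(F)cc3)ccc12`: 3300 nM

Compound 1 stands only at a limit, with no number behind it: the limit of > 20000 nM in this assay, at which 1 of the 2 values shown sits.

Compound 3 `CCN(CC)CCCC(C)Nc1ccc(NC(=O)c2cc(=O)[nH]c3cc(F)ccc23)cc1F` keeps the core of compound 1 and adds a side chain. The change is (4-(diethylamino)-1-methylbutyl)amino in place of hydrogen on an aromatic carbon, ortho to a fluoro group and para to a large group.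

Among the measured compounds shown here, one measured step bears on this, and only loosely: an at least 6.0-fold lower number from compound 1 to compound 2 (0.78 log units; beyond the scatter). That step replaces a fluoro group with 4-fluorophenyl, so it differs from the present change in both the group and the place. It does show that a larger substituent on compound 1 can bring a measurable value, with compound 2 at 3300 nM. A step of similar size toward a lower number is therefore expected in this assay, though a single example leaves this uncertain. The expected change is an at least 5.0-fold lower number from compound 1 to compound 3 (0.69 log units; beyond the scatter).

For compound 3 the estimated value is 4000 nM, with an expected range from 1000 nM to 16000 nM.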

Compound 3, half-maximal inhibitory concentration: > 20000 nM
Compound 3 gave a limit, no number; the forecaster's own chance of this, stated with the estimate: 20%; middle value at least 5.0-fold (0.69 log units) from the limit.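

Compound 1 and compound 3 both give a limit rather than a number in this assay, and no step between them can be read because they sit at the same limit: the limit of > 20000 nM in this assay, at which 2 of the 3 values shown sit.

The compounds shown leave open whether (4-(diethylamino)-1-methylbutyl)amino in place of hydrogen on an aromatic carbon changes the read-out at all.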